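The source may report more compounds than this note shows. Statements on the series, on what has been measured and on what is new or still open speak of the compounds shown alone.

Measured so far in an ADME assay on liver (Mus musculus, strain CD-1) for metabolic stability, read by LC-MS, using microsomes and NADPH, with a stated time of 5 min, tested at 1 uM; on this read-out higher numbers stand for a longer-lived compound and lower numbers for a shorter-lived compound:
- compound 1, `COc1ccc(NC(=O)C(=O)c2cn(C(C)C)c3ccccc23)cn1`: 0.0833 h
- compound 2, `COCCn1cc(C(=O)C(=O)Nc2ccc(OC(C)C)nc2)c2ccccc21`: 1.65 h
- compound 3, `COCC(C)n1cc(C(=O)C(=O)Nc2ccc(OC)nc2)c2ccccc21`: 0.267 h

Compound 3 stands second highest of the three numbers: compound 1 is its nearest neighbour, with a 3.2-fold higher number from compound 1 to compound 3 (0.51 log units; beyond the scatter) separating them, and compound 2 is furthest, its value sitting clearly higher than that of compound 3. Compound 2 differs from compound 3 in two places at once, so no single step can be read from that pair.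

Compound 4, `COc1ccc(NC(=O)C(=O)c2cn(CC3CCCO3)c3ccccc23)cn1`, is not yet measured. It differs from compound 3 in one place: (oxolan-2-yl)methyl in place of 1-(methoxymethyl)ethyl on an aromatic nitrogen. Among the measured compounds shown here, only one measured step bears on this position, that from compound 1 to compound 3, and it was modest. Since the new group keeps one hydrogen-bond acceptor and adds a five-membered non-aromatic ring with 1 hetero atom on the same aromatic nitrogen, no step beyond the scatter is expected for compound 4, with an expected shift of a 1.1-fold higher number from compound 3 to compound 4 (0.05 log units; within the scatter). The estimate for compound 4 in this assay is 0.3 h, with a range of 0.12 h to 0.8 h.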

Compound 4, half-life: 0.567 h
Compound 4: the middle estimate sits 1.9-fold (0.28 log units) below what was measured; the range from low to high includes it.
By their numbers in this assay, from the lowest: compound 1; then compound 3; then compound 4; then compound 2.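

In this assay, the group on the aromatic nitrogen still matters when the hydrogen-bond acceptor count stays the same: (oxolan-2-yl)methyl in place of 1-(methoxymethyl)ethyl gives a 2.1-fold higher number from compound 3 to compound 4 (0.33 log units; beyond the scatter), so these two oxygen-bearing groups are not interchangeable at this position. Set against isopropyl, the same group gives a 6.8-fold higher number from compound 1 to compound 4 (0.83 log units; beyond the scatter), which places both oxygen-bearing groups of compound 3 and compound 4 above isopropyl on this shared core. No measurement at hand explains why the ring-bearing group gives the longer half-life.

As far as these compounds go, whether the higher number depends on the ring oxygen or on the ring alone remains open, and a cyclopentylmethyl group on the same aromatic nitrogen would separate the two. Also open, from the compounds shown here alone, is whether a basic amine, such as a pyrrolidinylmethyl group, would fit this pattern.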